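Adding a methyl to the propylamino chain of compound 3

The source may hold more compounds than are shown below. What is called first, only, known or untested is meant among the compounds shown, and "the series" means these compounds.

Values in an ADME assay on the whole organism for inhibition, with Echinochloa crus-galli var. formosensis as the target, with a stated time of 4 days; on this read-out lower numbers stand for stronger inhibition and higher numbers for weaker inhibition:
compound 1 `CCN(c1nc(Cl)nc(N[C@H](C)c2ccccc2)n1)C(C)C` gives 52500 nM
compound 2 `CCNc1nc(Cl)nc(N[C@H](C)c2ccccc2)n1` gives 2690 nM
compound 3 `CCCNc1nc(Cl)nc(N[C@H](C)c2ccccc2)n1` gives 33100 nM

Among these three, compound 3 at 33100 nM cannot be told apart from compound 1, while compound 2 stands clearly apart from both. The next compound, compound 4 `CC[C@H](C)Nc1nc(Cl)nc(N[C@H](C)c2ccccc2)n1`, has not yet been measured in this assay. The difference from compound 3 is methyl in place of hydrogen on a saturated chain carbon bound to a nitrogen on an aromatic ring and a saturated chain carbon. Read one bond further out, propylamino becomes (sec-butyl)amino.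

Within the data shown here, three measured steps bear on this. The closest is a 12-fold higher number from compound 2 to compound 3 (1.09 log units; beyond the scatter), a large move to weaker inhibition on adding one methyl, though on a different chain carbon. The step of a 20-fold lower number from compound 1 to compound 2 (1.29 log units; beyond the scatter) is also large, and it shows how much the amino group can matter. By contrast, a 1.6-fold lower number from compound 1 to compound 3 (0.20 log units; within the scatter) stays within the scatter, so two larger amino groups gave indistinguishable numbers. Among the measured compounds shown here, no measured compound carries a methyl on this carbon, so the direction remains open. Compound 4 is therefore expected to stay in the range of compound 3 and compound 1, with no shift beyond the scatter. The expected result is a 1.1-fold lower number from compound 3 to compound 4 (0.04 log units; within the scatter). Compound 4 is estimated at 30000 nM, within an expected range from 7000 nM to 100000 nM.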

Compound 4, half-maximal inhibitory concentration: 52500 nM
Estimate against measurement, compound 4: 1.8-fold (0.24 log units) below, within the range that was stated.
By their numbers in this assay, from the lowest: compound 2; then compounds 3, 1 and 4 (each within the scatter of the next).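

Placing a methyl on a saturated chain carbon bound to a nitrogen on an aromatic ring and a saturated chain carbon gives the first measured step at this position in this assay, and a 1.6-fold higher number from compound 3 to compound 4 (0.20 log units; within the scatter) shows that propylamino and (sec-butyl)amino cannot be told apart here. Ethyl in place of hydrogen on that same carbon gives a 20-fold higher number from compound 2 to compound 4 (1.29 log units; beyond the scatter), whereas no change at the digits printed from compound 1 to compound 4 (within the scatter), so among the four compounds only compound 2 stands clearly apart, while the larger amino groups in the other three give numbers within the scatter of one another. Nothing available accounts for these numbers.

As far as these compounds go, it remains open how a smaller methylamino group, a ring-bearing cyclopropylamino group or a more branched tert-butylamino group would read in this assay, and whether the opposite configuration at the new methyl-bearing carbon would give a similar number. All four compounds also share the rest of the core, so the effect of this methyl is known only with that chlorine and that 1-phenylethylamino group in place.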